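Swapping a methoxyphenyl for a dimethylphenyl on sulfur

The source may hold more compounds than are shown below. What is called first, only, known or untested is meant among the compounds shown, and "the series" means these compounds.

Of the compounds shown here, three sharing one core have so far been tested in a functional assay on SMMC-7721 cells (Homo sapiens) for antiproliferative activity, read by CCK-8 assay, with a stated time of 72 h; a higher number here means a weaker inhibitor, a lower number a stronger inhibitor. Compound 1 `COc1ccc(SCc2ccc(C(=O)Nc3ccccc3N)cc2)cc1` gives 2170 nM. Compound 2 `Nc1ccccc1NC(=O)c1ccc(CSc2nccc(C(F)(F)F)n2)cc1`, which carries a different ring on the sulfur, gives 1890 nM, and compound 3 `COc1ccc(SCc2ccc(C(=O)Nc3ccccc3N)cc2)cc1OC` gives 3400 nM. Among these three numbers compound 1 stands second highest, with compound 2 nearest and compound 3 furthest, and both gaps fall within the usual scatter of repeated measurements.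

Compound 4 `Cc1cc(C)cc(SCc2ccc(C(=O)Nc3ccccc3N)cc2)c1` has not yet been measured. Its change from compound 1 is 3,5-dimethylphenyl in place of 4-methoxyphenyl on a sulfur. Among the compounds with values here, only one measured step touches the ring on the sulfur: a 1.6-fold higher number from compound 1 to compound 3 (0.20 log units; within the scatter), which stayed within the scatter. Within the data shown here, no measured pair exchanges the methoxy for methyl groups, so the change to compound 4 can be judged only by analogy. The expectation of a step within the scatter rests on two points: a 1.6-fold higher number from compound 1 to compound 3 (0.20 log units; within the scatter) was small, and compound 2, with a quite different ring on the sulfur, gives 1890 nM, close to compound 1. Compound 4 is therefore estimated at 2200 nM, with a range from 1000 nM to 5000 nM. The step expected is a 1.0-fold higher number from compound 1 to compound 4 (0.01 log units; within the scatter), meaning no change beyond the scatter.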

Compound 4, half-maximal inhibitory concentration: 2760 nM
Compound 4: the middle estimate sits 1.3-fold (0.10 log units) below what was measured; measured number inside the range.
By their numbers in this assay, from the lowest: compounds 2, 1, 4 and 3 (each within the scatter of the next).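

In this assay, the step to the 3,5-dimethylphenyl ring is a 1.3-fold higher number from compound 1 to compound 4 (0.10 log units; within the scatter). Within the data shown here, the earlier step to compound 3 kept its oxygen atoms on the ring on the sulfur, whereas this exchange leaves that ring with only carbon, going from 1 hydrogen-bond acceptor to 0 at the same count of 8 heavy atoms, so this pair is the first to show that a ring with no methoxy group can stand on the sulfur without a step beyond the scatter. No separate measurement on these compounds is available to say what lies behind this result.

The exchange also alters the number of groups on the ring and where they sit, so this single pair cannot show which of these matters, or whether the two alterations offset each other. All the rings on the sulfur shown here carry uncharged groups, which leaves open whether this position would stay as tolerant of an amine or a carboxylic acid on the ring, or of a longer chain in place of the ring.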